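Benzyl in Place of Cyclohexyl, Tested a Second Time

The compounds below may be only part of what the source reports. "The series", "measured", "known", "first", "only" and "open" are said of these compounds alone.

Compound 1 `O=Cc1ccc(-c2cn3ccnc3c(-c3ccc4ncn(C5CCCCC5)c4c3)n2)cc1` gives 98% in a functional assay on T47D cells (Homo sapiens) for inhibition, read by sulforhodamine B assay, with a stated time of 48 h, tested at 10 uM; on this read-out lower numbers stand for less inhibition and higher numbers for more inhibition at the one concentration tested (going by the name of the read-out). Compound 2 `O=Cc1ccc(-c2cn3ccnc3c(-c3ccc4ncn(Cc5ccccc5)c4c3)n2)cc1` carries benzyl in place of cyclohexyl on an aromatic nitrogen and in this assay compound 2 gives 98%, so that the step is no change at the digits printed from compound 1 to compound 2 (within the scatter). Compound 3 `c1cn2cc(-c3ccc4c(c3)ncn4C3CCCCC3)nc(-c3ccc4ncn(C5CCCCC5)c4c3)c2n1` in this assay gives 44.7%; the difference between the core of compound 3 and the core of compound 1 is not broken down here. Compound 4 `c1ccc(Cn2cnc3ccc(-c4nc(-c5ccc6c(c5)ncn6C5CCCCC5)cn5ccnc45)cc32)cc1` carries the same change as before, (benzyl in place of cyclohexyl on an aromatic nitrogen). The step is expected to be a number 0.3 percentage points higher from compound 3 to compound 4 (within the scatter), resting on the earlier pair because no change at the digits printed from compound 1 to compound 2 (within the scatter) showed no movement, although that pair sat at a high number in this assay and leaves room for doubt. The estimate for compound 4 in this assay is 45%, between 28% and 62%.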

Compound 4, a percentage reported as inhibition, at one concentration (the size of the read-out at that concentration, not a potency): -2.12%
For compound 4 the middle estimate is 47.1 percentage points above the measured one; the measured number lies below the stated range.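

Moved to the second core, benzyl in place of cyclohexyl on an aromatic nitrogen gives a number 46.8 percentage points lower from compound 3 to compound 4 (beyond the scatter) in this assay. The change therefore does not carry over at one size between these two cores: the same change on two cores in this assay, no change at the digits printed (within the scatter) from compound 1 to compound 2 and a number 46.8 percentage points lower (beyond the scatter) from compound 3 to compound 4, 46.8 percentage points apart, beyond the scatter of two such steps This does not show why the two steps differ, and two pairs tested at a single concentration set no rule for any other core in the series.

The compounds shown leave open how a longer chain or an amine on that aromatic nitrogen would fare on either core. They also leave open how the two steps would compare at other concentrations.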